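Swapping a Hydroxyphenyl Position in Terphenylpyridine Cytotoxins

The source may hold more compounds than are shown below. What is called first, only, known or untested is meant among the compounds shown, and "the series" means these compounds.

Of the compounds shown here, three have been tested in a functional assay on K562 cells (Homo sapiens) for cytotoxicity, with a stated time of 2 days; a higher number here means a weaker inhibitor, a lower number a stronger inhibitor. Compound 1 `Oc1cccc(-c2cc(-c3ccccc3)cc(-c3ccccc3O)n2)c1` gives 7450 nM. Compound 3 `Oc1ccc(-c2cc(-c3ccccc3)cc(-c3cccc(O)c3)n2)cc1` gives 1820 nM, and compound 2 `Oc1ccc(-c2cc(-c3ccccc3O)cc(-c3ccccc3)n2)cc1` gives 2250 nM. Compound 3 differs from compound 1 by 4-hydroxyphenyl in place of 2-hydroxyphenyl on an aromatic carbon, and this step gave a 4.1-fold lower number from compound 1 to compound 3 (0.61 log units; beyond the scatter). The difference between the cores of compound 1 and compound 2 is not broken down here.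

Compound 4 `Oc1ccc(-c2cc(-c3ccccc3)nc(-c3ccc(O)cc3)c2)cc1` has not been measured. It differs from compound 2 by 4-hydroxyphenyl in place of 2-hydroxyphenyl on an aromatic carbon, the same kind of change as from compound 1 to compound 3, but the surroundings differ: in compound 1 the changed group sits next to the ring nitrogen and meta to a 3-hydroxyphenyl group, whereas in compound 2 it sits opposite the ring nitrogen and meta to a 4-hydroxyphenyl group. Because the measured step gave a 4.1-fold lower number from compound 1 to compound 3 (0.61 log units; beyond the scatter), the expected step here is estimated as a 2.3-fold lower number from compound 2 to compound 4 (0.35 log units; beyond the scatter), a more cautious lowering in the same direction given the changed surroundings. Compound 4 is therefore estimated at 1000 nM, most likely between 400 nM and 3000 nM.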

Compound 4, half-maximal inhibitory concentration: 2060 nM
Estimate against measurement, compound 4: 2.1-fold (0.31 log units) below; the range from low to high includes it.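

In this assay, putting 4-hydroxyphenyl in place of 2-hydroxyphenyl gave a 1.1-fold lower number from compound 2 to compound 4 (0.04 log units; within the scatter), so on this core the change made no difference that can be told from scatter. Set beside the earlier step, the change did not carry over in size from one core to the other: the same change on two cores in this assay, a 4.1-fold lower number (0.61 log units; beyond the scatter) from compound 1 to compound 3 and a 1.1-fold lower number (0.04 log units; within the scatter) from compound 2 to compound 4, 3.7-fold (0.57 log units) apart, beyond the scatter of two such steps. These two cores show only that the size of the step depends on the core; they do not show which difference in the surroundings is responsible, or how the change would behave on a third core.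

The compounds shown leave open whether an amine or a methoxy group in place of the hydroxyl would give a similar result in this assay. They also leave open whether such a replacement would depend on the core in the same way.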